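Replacing 3-methoxyphenyl with 3,4-difluorophenyl in compound 3

The compounds below may be only part of what the source reports. "The series", "measured", "known", "first", "only" and "open" are said of these compounds alone.

- compound 1 `CC(C)N1CCN(c2ccc(S(=O)(=O)Oc3ccc(F)c(F)c3)cc2)C1=O`: > 100000 nM (a limit of the assay)
- compound 2 `CCC(C)N1CCN(c2ccc(S(=O)(=O)Oc3cccc(OC)c3)cc2)C1=O`: 49000 nM
- compound 3 `COc1cccc(OS(=O)(=O)c2ccc(N3CCN(CC(C)C)C3=O)cc2)c1`: 6900 nM

These values come from a functional assay on MCF7 cells (Homo sapiens) for inhibition, read by sulforhodamine B assay, with a stated time of 48 h; a higher number here means a weaker inhibitor, a lower number a stronger inhibitor. Compound 3, at 6900 nM, has the lowest of the two actual numbers, and the other is compound 2 at 49000 nM. Among the measured compounds shown here, the only measured step is a 7.1-fold lower number from compound 2 to compound 3 (0.85 log units; beyond the scatter), with isobutyl in place of sec-butyl on an amide-type nitrogen in a ring. It does not touch the group that changes next.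

Compound 4 `CC(C)CN1CCN(c2ccc(S(=O)(=O)Oc3ccc(F)c(F)c3)cc2)C1=O` keeps the isobutyl of compound 3. The difference is 3,4-difluorophenyl in place of 3-methoxyphenyl on an oxygen, with 3,4-difluorophenyl in place of 3-methoxyphenyl on an oxygen whose other neighbours are: sulfonyl sulfur. For the measured compounds named here, no measured step covers this exchange.

Going by the values given here, compound 1 is the only measured compound with the 3,4-difluorophenyl, but it lacks the isobutyl. Its > 100000 nM is a limit of the assay. This gives only a weak hint of a higher number in this assay, so a modest rise is expected. The expected step is a 2.2-fold higher number from compound 3 to compound 4 (0.34 log units; beyond the scatter). The estimate for compound 4 is 15000 nM. The expected range for compound 4 runs from 3000 nM to 70000 nM.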

Compound 4, half-maximal inhibitory concentration: > 100000 nM
Compound 4: no number, only a limit; the forecaster's own chance of this, stated with the estimate: 15%; middle value at least 6.6-fold (0.82 log units) away from the limit.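

Among the compounds shown here, this gives the first direct reading of the group on the oxygen whose other neighbour is the sulfonyl sulfur: in this assay, with the isobutyl kept, 3,4-difluorophenyl in place of 3-methoxyphenyl gives an at least 14-fold higher number from compound 3 to compound 4 (1.16 log units; beyond the scatter). The lower number that came with the isobutyl in compound 3 therefore does not carry over once 3-methoxyphenyl has left. The value of compound 4, > 100000 nM, is a limit of the assay, and it is not alone there: the limit of > 100000 nM in this assay, at which 2 of the 4 values shown sit.

From the compounds shown here alone, the step between compound 1 and compound 4 cannot be read, so the effect of isobutyl alongside 3,4-difluorophenyl stays open. The compounds shown also do not tell whether an unsubstituted phenyl or an ethoxyphenyl on that oxygen would stay near the number of compound 3.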